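Extending an Oxime Ether with a Phenyl Group

The source may report more compounds than this note shows. Statements on the series, on what has been measured and on what is new or still open speak of the compounds shown alone.

Within the data shown here, compound 2 `CO/N=C/c1c(-c2ccccc2)[nH]c2ccccc12` stands at the lower of the two numbers measured so far in an assay on isolated protein for inhibition of Aromatase (Homo sapiens), read by fluorescence, using NADPH, with a stated time of 30 min, tested at 50 uM; a higher number here means more inhibition at the concentration tested (going by the name of the read-out), a lower number less inhibition: compound 2 gives 24.7%, while compound 1 `Cn1c(-c2ccc(Cl)c(Cl)c2)cc2cc(N)ccc21` gives 42%, a gap beyond the usual scatter. Compound 3 `C(=N/OCc1ccccc1)\c1c(-c2ccccc2)[nH]c2ccccc12` has not yet been measured. It differs from compound 2 by phenyl in place of hydrogen on a saturated chain carbon bound to an oxygen. Among the measured compounds shown here, no measured pair shows the effect of such a change, so its size is uncertain; a modest rise in inhibition is expected, with the step estimated at a number 10.3 percentage points higher from compound 2 to compound 3 (beyond the scatter). Compound 3 is therefore expected to give about 35%, within a range from 15% to 58%.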

Compound 3, a percentage reported as inhibition, at one concentration (the size of the read-out at that concentration, not a potency): 23.3%
For compound 3 the middle estimate is 11.7 percentage points above the measured one; measured number inside the range.
By their numbers in this assay, from the lowest: compounds 3 and 2 (each within the scatter of the next); then compound 1.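

In this assay, exchanging methoxy for benzyloxy gives a number 1.4 percentage points lower from compound 2 to compound 3 (within the scatter), so the two compounds cannot be told apart. This first direct test of the change shows that adding a phenyl on this saturated chain carbon bound to an oxygen brings no gain in inhibition beyond the scatter, and no clear loss either. No measurement shown here offers an explanation for this result. Still open, from the compounds shown here alone, is whether an amine or a carboxylic acid in place of this phenyl would change the number. A longer chain carrying the phenyl is equally untested among the compounds shown.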